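The source may hold more compounds than are shown below. What is called first, only, known or untested is meant among the compounds shown, and "the series" means these compounds.

Compound 1 `Brc1cn2ccnc2c(-c2ccc3ncn(C4CCCCC4)c3c2)n1` gives 13.1% in a functional assay on HCT-15 cells (Homo sapiens) for inhibition, read by sulforhodamine B assay, with a stated time of 48 h, tested at 10 uM; a lower number here means less inhibition, a higher number more inhibition at the concentration tested (going by the name of the read-out); compound 2 `c1ccc2c(-c3cn4ccnc4c(-c4ccc5ncn(C6CCCCC6)c5c4)n3)cccc2c1` gives 4.46%; compound 3 `Clc1ccc(-c2cn3ccnc3c(-c3ccc4ncn(C5CCCCC5)c4c3)n2)cc1` gives 15.5%.

Compound 3 has the highest of the three numbers, though its gap to compound 1 is within the scatter, and only its gap to compound 2 is beyond it. Compound 4 `c1csc(-c2cn3ccnc3c(-c3ccc4ncn(C5CCCCC5)c4c3)n2)c1` differs from compound 3 in one place: thiophen-2-yl in place of 4-chlorophenyl on an aromatic carbon. Every measured step also changes the group on this aromatic carbon, so all bear on it: a number 2.4 percentage points higher from compound 1 to compound 3 (within the scatter), a number 8.6 percentage points lower from compound 1 to compound 2 (within the scatter) and a number 11 percentage points higher from compound 2 to compound 3 (beyond the scatter). Two of three such swaps stayed within the scatter, and the one beyond it was modest. A small step, if any, is therefore expected for compound 4, with no confident direction, as a number 4.5 percentage points lower from compound 3 to compound 4 (within the scatter). Compound 4 is estimated to give 11%, between 2% and 22%.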

Compound 4, a percentage reported as inhibition, at one concentration (the size of the read-out at that concentration, not a potency): 2.33%
Estimate against measurement, compound 4: 8.7 percentage points above, and the stated range covers the measured number.
By their numbers in this assay, from the lowest: compounds 4, 2, 1 and 3 (each within the scatter of the next, the first and the last beyond it).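

In this assay, among these compounds, the swap to thiophen-2-yl on this aromatic carbon gives a number 13.2 percentage points lower from compound 3 to compound 4 (beyond the scatter) and a number 10.8 percentage points lower from compound 1 to compound 4 (beyond the scatter), so this group is the first here to stand clear of both 4-chlorophenyl and bromo. Against naphthalen-1-yl the change is only a number 2.1 percentage points lower from compound 2 to compound 4 (within the scatter), so a group of 5 heavy atoms and a much larger fused group cannot be told apart. Nothing available explains these differences. From the compounds shown here alone, it remains open whether an amine or a carboxylic acid on this carbon would take the number clearly past compound 3 at 15.5%.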